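From Methyl to Bromo at a Tolerated Limit

The source may hold more compounds than are shown below. What is called first, only, known or untested is meant among the compounds shown, and "the series" means these compounds.

In a toxicity assay on THP-1 cells (Homo sapiens) for inhibition (a higher number here means that more compound is tolerated, a lower number that less compound is tolerated), compound 3 (`Cc1cccc(-c2cnc(NC(=O)c3ccc(F)cc3)n2C)c1`) gives > 100000 nM, which is a limit and not a number. Compound 1 (`Cc1ccccc1-c1cnc(NC(=O)c2ccc(F)cc2)n1C`) gives > 50000 nM, also a limit. Compound 2 (`Cn1c(-c2ccc(C#N)cc2)cnc1NC(=O)c1ccc(F)cc1`) gives > 50000 nM, again a limit.

Compound 4 (`Cn1c(-c2cccc(Br)c2)cnc1NC(=O)c1ccc(F)cc1`) differs from compound 3 by bromo in place of methyl on an aromatic carbon, meta to a large group: bromo in place of methyl on an aromatic carbon.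

Two measured steps change the same aryl group and so bear on this one. They are a step that the two limits leave unreadable from compound 1 to compound 3 and a step that the two limits leave unreadable from compound 2 to compound 3. Neither has a readable size, so they offer no measured size or direction to carry over, and no step beyond the scatter is expected in this assay. The expected change is an at least 1.4-fold lower number from compound 3 to compound 4 (0.15 log units; that floor lies within the scatter). A further limit is the likeliest report for the new compound. If a number is reported, the estimate for compound 4 is 70000 nM, with an expected range from 30000 nM to 120000 nM.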

Compound 4, half-maximal cytotoxic concentration: > 50000 nM
Compound 4 gave a limit, no number; the forecaster's own chance of this, stated with the estimate: 80%; the middle value is on the limit's open side.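

In this assay compound 4 gives > 50000 nM, which is a limit and not a number. Its steps from compound 1, compound 2 and compound 3 cannot be read. The compounds shown leave open at what concentration any of the four would become half-maximally cytotoxic.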